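Series notes: third chloro added to compound 1

The source may hold more compounds than are shown below. What is called first, only, known or untested is meant among the compounds shown, and "the series" means these compounds.

Compound 1 `Clc1ccc(-c2nc(-c3ccccc3)no2)c(Cl)c1` is the reference point. Among the measured compounds shown here, in an assay on cells (Epithelial cell, strain FVB/N) for agonist activity at aryl hydrocarbon receptor (Mus musculus), read by microscopy, with a stated time of 144 h, in the presence of a further agent that is not named here (a higher number here means that more compound is needed for the effect, a lower number that less compound is needed), compound 1 gives 1200 nM, the lowest of the three numbers so far. Compound 2 `Nc1cc(Cl)ccc1-c1nc(-c2ccccc2)no1` replaces one chloro with amino; in this assay compound 2 gives 1400 nM, and the step of a 1.2-fold higher number from compound 1 to compound 2 (0.07 log units; within the scatter) lies within the scatter. Compound 3 `Nc1cc(C(F)(F)F)ccc1-c1nc(-c2ccccc2)no1` carries trifluoromethyl in place of the remaining chloro of compound 2; in this assay compound 3 gives 3200 nM, and the step of a 2.3-fold higher number from compound 2 to compound 3 (0.36 log units; beyond the scatter) is modest but beyond the scatter. Compound 1 thus stands closest to compound 2 and furthest from compound 3.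

Compound 4 `Clc1ccc(-c2nc(-c3ccccc3)no2)c(Cl)c1Cl` is not yet measured. The change from compound 1 is chloro in place of hydrogen on an aromatic carbon: chloro enters on an aromatic carbon of the six-membered aromatic ring of carbon only, ortho to two chloro groups and meta to a large group. For the measured compounds named here, neither measured step touches this position; both concern exchanges of the groups already present, and the only step beyond the scatter, a 2.3-fold higher number from compound 2 to compound 3 (0.36 log units; beyond the scatter), was a swap rather than an addition. Going by the values given here, no measured step therefore bears directly on the change. With nothing to point either way, the expected step of no change at the digits printed from compound 1 to compound 4 (within the scatter) in this assay is none beyond the scatter. Compound 4 is estimated at 1200 nM, with a range from 450 nM to 3200 nM.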

Compound 4, half-maximal effective concentration: > 10000 nM
Compound 4 ended at the assay's limit (the forecaster's own chance of this, stated with the estimate: 5%); at least 8.3-fold (0.92 log units) between middle value and limit.
By their numbers in this assay, from the lowest: compounds 1 and 2 (each within the scatter of the next); then compound 3. At a limit, above all of these: compound 4.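

Working from the core of compound 1, this position, which carries hydrogen in compounds 1, 2 and 3, proves not to be neutral to substitution: in this assay, chloro in place of hydrogen, ortho to two chloro groups and meta to a large group, gives an at least 8.3-fold higher number from compound 1 to compound 4 (0.92 log units; beyond the scatter). Exchanges of the groups already present had moved the number far less, with a 1.2-fold higher number from compound 1 to compound 2 (0.07 log units; within the scatter) and a 2.3-fold higher number from compound 2 to compound 3 (0.36 log units; beyond the scatter), so the addition of one chloro here outweighs either swap, and the series now holds a change that takes a compound out of the measurable range. Compound 4 gives > 10000 nM, which is a limit of the assay and not a number, so the step has a lower bound but no measured size, and this is the only such value in the series: the limit of > 10000 nM in this assay, at which 1 of the 4 values shown sits.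

As far as these compounds go, whether fluoro, methyl or methoxy at this position would keep the number near those of compounds 1, 2 and 3, or whether any addition here has the same outcome, stays open. Also open, from the compounds shown here alone, is whether chloro at this position would give a similar step with amino on the ring, as in compound 2, or with trifluoromethyl, as in compound 3.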